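A side chain exchanged on compound 2

The source may hold more compounds than are shown below. What is called first, only, known or untested is meant among the compounds shown, and "the series" means these compounds.

Compound 1 `Cc1nc(N(C)c2ccc([Se]C#N)c(C)c2)c2ccccc2n1` gives 13 nM in a functional assay on HCT-116 cells (Homo sapiens) for inhibition, read by MTT assay, with a stated time of 48 h; a higher number here means a weaker inhibitor, a lower number a stronger inhibitor
Compound 2 `COc1ccc(N(C)c2nc(C)nc3ccccc23)cc1C(=O)OCCC[Se]C#N` gives 720 nM in this assay

Compound 2 has the higher number of the two, and its gap from compound 1 lies beyond the usual scatter. Compound 3 `COc1ccc(N(C)c2nc(C)nc3ccccc23)cc1OCCCC[Se]C#N` has not yet been measured. Its change from compound 2 is a group of 8 heavy atoms (5 carbon, 1 nitrogen, 1 oxygen, 1 selenium; no ring) in place of a group of 9 heavy atoms (5 carbon, 1 nitrogen, 2 oxygen, 1 selenium; no ring), on an aromatic carbon and it sits ortho to a methoxy group and meta to a large group. Among the measured compounds shown here, no measured pair shows such a change, so only a small move towards a lower number, not beyond the scatter, is expected in this assay for now. The expected step is a 1.6-fold lower number from compound 2 to compound 3 (0.20 log units; within the scatter) and it remains an estimate. For compound 3 the estimated value is 450 nM with an expected range from 120 nM to 1700 nM until the measurement is available.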

Compound 3, half-maximal inhibitory concentration: 512 nM
Compound 3: the middle estimate sits 1.1-fold (0.06 log units) below what was measured, and the stated range covers the measured number.
By their numbers in this assay, from the lowest: compound 1; then compounds 3 and 2 (each within the scatter of the next).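

In this assay, among the compounds shown here, exchanging the group of 9 heavy atoms for the group of 8 heavy atoms, on an aromatic carbon ortho to a methoxy group, gives a 1.4-fold lower number from compound 2 to compound 3 (0.15 log units; within the scatter), the first reading of a change at this position. The two side chains, one with a double bond outside aromatic rings and a third hydrogen-bond acceptor, cannot be told apart here. Nothing available accounts for this result. As far as these compounds go, it remains open whether an amine, a carboxylic acid or a longer chain at this position would shift the number beyond the scatter.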